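Swapping the amine on the side chain of compound 3

The source may hold more compounds than are shown below. What is called first, only, known or untested is meant among the compounds shown, and "the series" means these compounds.

Measured so far:
compound 1, `CC(=O)Oc1ccc(C(=O)Nc2cc3ccc(OCCC4CCCCN4)c(C)c3oc2=O)cc1CC=C(C)C`: 710 nM
compound 2, `CC(=O)Oc1ccc(C(=O)Nc2cc3ccc(OCC4CCCNC4)c(C)c3oc2=O)cc1CC=C(C)C`: 820 nM
compound 3, `CCN(CC)CCCOc1ccc2cc(NC(=O)c3ccc(O)c(CC=C(C)C)c3)c(=O)oc2c1C`: 6390 nM

In a functional assay on MCF7 cells (Homo sapiens) for antiproliferative activity (on this read-out lower numbers stand for stronger inhibition and higher numbers for weaker inhibition), compound 3 gives the highest number of the three, so it is the weakest of these compounds. On these data alone, the next compound, compound 4, `CC(C)=CCc1cc(C(=O)Nc2cc3ccc(OCCCN(C)C4CCCCC4)c(C)c3oc2=O)ccc1O`, is untested. It differs from compound 3 in one spot: cyclohexyl(methyl)amino in place of diethylamino on a saturated chain carbon, three bonds along the chain from an oxygen on an aromatic ring. Among the measured compounds shown here, the only step measured between close compounds, a 1.2-fold higher number from compound 1 to compound 2 (0.06 log units; within the scatter), concerns the amine end of the same side chain but not this exact exchange, so it gives limited guidance; it suggests such changes can be small. Without a closer precedent, compound 4 is expected to stay near compound 3, with a 1.4-fold lower number from compound 3 to compound 4 (0.15 log units; within the scatter), and its estimated value is 4500 nM, within 1500 nM to 13000 nM.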

Compound 4, half-maximal inhibitory concentration: 1080 nM
For compound 4 the middle estimate is 4.2-fold (0.62 log units) above the measured one; measured number outside the range, below it.
By their numbers in this assay, from the lowest: compounds 1, 2 and 4 (each within the scatter of the next); then compound 3.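

In this assay, cyclohexyl(methyl)amino in place of diethylamino gives a 5.9-fold lower number from compound 3 to compound 4 (0.77 log units; beyond the scatter), so the amine at the end of this chain can change the reading beyond the scatter, which the earlier step, within the scatter, did not show. The entering group adds a six-membered carbon ring and more heavy atoms, while its hydrogen-bond donor and acceptor counts stay the same. No measurement available here explains the difference. On these data alone, it remains open whether the ring or simply the added carbon matters. Dipropylamino, which has no ring, at the same place would help separate the two.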